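Series notes: from compound 2 to compound 3

The compounds below may be only part of what the source reports. "The series", "measured", "known", "first", "only" and "open" are said of these compounds alone.

Measured so far:
compound 1, `C[C@@H]1O[C@@H](OCC#Cc2c(-c3ccccc3)oc3ccccc23)C[C@H](N)[C@@H]1O`, 77.8% in an assay on isolated protein for inhibition of DNA topoisomerase 1 (Homo sapiens), with a stated time of 30 min, tested at 100 uM; a higher number here means more inhibition at the concentration tested (going by the name of the read-out), a lower number less inhibition;
compound 2, `C[C@@H]1O[C@@H](OCC#Cc2c(-c3ccccc3)[nH]c3ccccc23)CC[C@@H]1N`, 4% in this assay.

For the measured compounds named here, compound 2 stands lowest of the two numbers; compound 1 lies higher by a margin beyond the scatter, though the two differ in more than one place, so no single step is drawn between them. Compound 3, `C[C@@H]1O[C@@H](OCC#Cc2c(-c3ccccc3)[nH]c3ccccc23)C[C@H](N)[C@H]1O`, carries the change (a group of 9 heavy atoms (6 carbon, 1 nitrogen, 2 oxygen; one six-membered non-aromatic ring with 1 hetero atom) in place of a group of 8 heavy atoms (6 carbon, 1 nitrogen, 1 oxygen; one six-membered non-aromatic ring with 1 hetero atom), on an oxygen on a saturated carbon). The entering group has one more oxygen and one more hydrogen-bond donor than the leaving one. With no measured step of this kind in hand, a rise is expected for compound 3, of size a number 31 percentage points higher from compound 2 to compound 3 (beyond the scatter), though it could also stay within the scatter. Compound 3 is estimated at 35%, in the range 5% to 75%.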

Compound 3, a percentage reported as inhibition, at one concentration (the size of the read-out at that concentration, not a potency): 8.2%
Beside the measured number, compound 3's estimate is 26.8 percentage points above it, within the range that was stated.
By their numbers in this assay, from the lowest: compounds 2 and 3 (each within the scatter of the next); then compound 1.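

On an oxygen on a saturated carbon, the group with one more oxygen and one more hydrogen-bond donor replaces 5-amino-6-methyloxan-2-yl, giving a number 4.2 percentage points higher from compound 2 to compound 3 (within the scatter) in this assay. This first readable step at this position shows that, on the shared core, the exchange does not separate the two compounds in this read-out. No available evidence bears on this result.

Going by these compounds, whether a simple methyl or a dimethylamino-bearing chain on that oxygen would shift the inhibition remains open. So does the outcome of the same exchange on the core of compound 1.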